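Replacing an anilino group with a carboxylic acid chain

The source may report more compounds than this note shows. Statements on the series, on what has been measured and on what is new or still open speak of the compounds shown alone.

Measured compounds, each in an assay for inhibition of Receptor tyrosine-protein kinase erbB-3 variant L858R (Homo sapiens), read by mobility shift assay, with a stated time of 10 min; a higher number here means a weaker inhibitor, a lower number a stronger inhibitor:
compound 1 `O=C(Nc1cc(Nc2ccc(Cl)cc2)ncn1)c1ccc(F)cc1`, compound 1 gives 1610 nM
compound 2 `COc1cccc(Nc2cc(Nc3cccc(Cl)c3)ncn2)c1`, compound 2 gives 1570 nM
compound 3 `Clc1ccc(Nc2cc(Nc3cccc(Cl)n3)ncn2)cc1`, compound 3 gives 236 nM

Compound 2 stands in the upper part of this small set. Compound 2 and compound 1 give numbers that lie within the usual scatter of each other, so no order between them can be read. Compound 3 gives a lower number, and the gap from compound 2 down to compound 3 lies beyond the scatter; compound 3 therefore shows the strongest inhibition of the three.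

The step under consideration leads from compound 2 to compound 4 `COc1cccc(Nc2cc(NC(=O)CCCC(=O)O)ncn2)c1`. The change is (3-carboxypropyl)carbonyl in place of 3-chlorophenyl on a nitrogen on an aromatic ring. A carboxylic acid on a short chain thus takes the place of the aromatic amine substituent on that nitrogen. Among the compounds with values here, compound 1 shows that an amide on this nitrogen is tolerated, but no measured compound carries an acid chain there, so the step cannot be anchored to a measured pair.

For compound 4 the step of a 3.8-fold higher number from compound 2 to compound 4 (0.58 log units; beyond the scatter) is expected, that is, a move towards weaker inhibition that goes beyond the scatter. Compound 4 is estimated at 6000 nM, with a range from 1500 nM to 25000 nM.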

Compound 4, half-maximal inhibitory concentration: 31 nM
Compound 4: the middle estimate sits 190-fold (2.29 log units) above what was measured; measured number below the stated range.
By their numbers in this assay, from the lowest: compound 4; then compound 3; then compounds 2 and 1 (each within the scatter of the next).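

In this assay, putting (3-carboxypropyl)carbonyl in place of 3-chlorophenyl on a nitrogen on an aromatic ring gives a 51-fold lower number from compound 2 to compound 4 (1.70 log units; beyond the scatter) and thus a large move towards stronger inhibition. The earlier compounds shown here all kept an aromatic ring in the groups on both nitrogens, so they could not show that this position accepts an open chain with no ring, ending in a carboxylic acid, and that such a chain can give a far lower number than the 3-chlorophenyl of compound 2. Nothing available bears on the reason for a step of this size.

The compounds shown leave open which part of the new group matters: the carboxylic acid at the chain end, the amide carbonyl on the nitrogen, or the chain that joins them, and a methyl ester, a primary amide, a terminal amine or a shorter or longer chain would each help to separate these. As far as these compounds go, it also remains open whether the same chain would have a similar effect when the 3-methoxyphenyl group on the other nitrogen is replaced by another group.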